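From 3-bromophenyl to 2-chlorophenyl on the shared core

A few compounds are considered here, and "the series" means these few. Any claim that something is new, unique, unknown or untested is made for them only; others in the source may bear on it.

In a functional assay on the whole organism (strain Kunming) with Mus musculus as the target, with a stated time of 0.5 h (on this read-out higher numbers stand for an effect only at larger amounts of compound and lower numbers for an effect already at smaller amounts), compound 2 (`COc1cc(OC)c(OC)cc1/C=C/COC(=O)/C=C/c1cccc(Br)c1`) gives 175 umol/kg and compound 1 (`COc1cc(OC)c(OC)cc1/C=C/COC(=O)/C=C/c1ccc(Br)cc1`) gives 143 umol/kg and these two values lie within the scatter of each other. Going by the values given here, compound 2 therefore has no separate standing among the only two numbers available so far. The change to compound 3 (`COc1cc(OC)c(OC)cc1/C=C/COC(=O)/C=C/c1ccccc1Cl`) is 2-chlorophenyl in place of 3-bromophenyl on a double-bonded chain carbon bound to a double-bonded chain carbon on a double-bonded chain carbon bound to a double-bonded chain carbon, while the rest of the structure stays the same. Among the compounds with values here, the only measured step that bears on this is a 1.2-fold higher number from compound 1 to compound 2 (0.09 log units; within the scatter) with 3-bromophenyl in place of 4-bromophenyl. That step stays within the scatter, but it covers only the two bromophenyl groups. Within the data shown here, no measured compound carries 2-chlorophenyl, so the data offer no direct guide to this group and the expected range has to stay wide. In this assay the expected size of the change is a 1.1-fold lower number from compound 2 to compound 3 (0.04 log units; within the scatter) and no shift beyond the scatter is predicted in either direction. For compound 3 the estimate is 160 umol/kg with an expected range from 85 umol/kg to 300 umol/kg around it.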

Compound 3, dose for half-maximal effect: 151 umol/kg
For compound 3 the middle estimate is 1.1-fold (0.03 log units) above the measured one; the measured number falls inside the stated range.
By their numbers in this assay, from the lowest: compounds 1, 3 and 2 (each within the scatter of the next).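

Going by these compounds alone, until this result, the place on a double-bonded chain carbon bound to a double-bonded chain carbon had been seen only with bromophenyl groups. Compound 3 extends the picture to a chlorine-bearing phenyl group in this assay: the step reads a 1.2-fold lower number from compound 2 to compound 3 (0.06 log units; within the scatter) against 3-bromophenyl and a 1.1-fold higher number from compound 1 to compound 3 (0.02 log units; within the scatter) against 4-bromophenyl. Across these three compounds, neither exchange moves the number beyond the scatter, although each one changes the halogen and its printed ring number together, so the two changes cannot be told apart here, and nothing available explains the result.

The compounds shown leave open whether 2-bromophenyl or 3-chlorophenyl would fall in the same range, which would separate the halogen from its ring number. They also leave open whether the flat picture extends beyond halogen-bearing phenyl groups, for example to unsubstituted phenyl, a methoxyphenyl, or a phenyl ring carrying an amine or a carboxylic acid.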